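A few compounds are considered here, and "the series" means these few. Any claim that something is new, unique, unknown or untested is made for them only; others in the source may bear on it.

Measured so far, all three at the limit of the assay:

- compound 1, `C=CCSc1nnc(-c2cc(OC)c(OC)c(OC)c2)n1N1C(=O)c2ccccc2C1=O`: in a functional assay on HepG2 cells (Homo sapiens) for cytotoxicity, read by MTT assay, with a stated time of 48 h (on this read-out lower numbers stand for stronger inhibition and higher numbers for weaker inhibition), compound 1 gives > 200000 nM, a limit.
- compound 2, `COc1cc(-c2nnc(SC)n2N2C(=O)c3ccccc3C2=O)cc(OC)c1OC`: in this assay compound 2 gives > 200000 nM, a limit.
- compound 3, `COc1cc(-c2nnc(SCc3ccccc3)n2N2C(=O)c3ccccc3C2=O)cc(OC)c1OC`: in this assay compound 3 gives > 200000 nM, a limit.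

Compound 3 therefore stands nowhere in particular on the numbers shown: its value is only a limit, and the other two values are limits as well, so that all three sit together (the limit of > 200000 nM in this assay, at which 3 of the 3 values shown sit). The three steps between them, a step that the two limits leave unreadable from compound 1 to compound 2, a step that the two limits leave unreadable from compound 1 to compound 3 and a step that the two limits leave unreadable from compound 2 to compound 3, cannot be read in size or direction, since the limit hides what happens on either side of it. The shared core carries a sulfur-bound chain, and so far changing the group on that chain has not brought any compound into the measurable range.

Compound 4, `COc1cc(-c2nnc(SCC(=O)c3ccc(Br)cc3)n2N2C(=O)c3ccccc3C2=O)cc(OC)c1OC`, is the next change on that chain: (4-bromophenyl)carbonyl in place of phenyl on a saturated chain carbon bound to a sulfur. Among the measured compounds shown here, none of the measured steps gives a readable size, so no step of a known size bears on this change, and there is no basis for expecting a move beyond the scatter in either direction in this assay. The expectation for compound 4 is accordingly anchored at the limit: an estimated 150000 nM, in a range from 40000 nM to 300000 nM. The step this estimate means, an at least 1.3-fold lower number from compound 3 to compound 4 (0.12 log units; that floor lies within the scatter), is expected to be small at best.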

Compound 4, half-maximal inhibitory concentration: 27700 nM
Compound 4: middle estimate off by 5.4-fold (0.73 log units), on the high side, outside the stated range (below it).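

In this assay, the group on the saturated chain carbon bound to a sulfur can bring this series into the measurable range, which vinyl, hydrogen and phenyl at that place did not do. Placing (4-bromophenyl)carbonyl there gives an at least 7.2-fold lower number from compound 3 to compound 4 (0.85 log units; beyond the scatter) when it replaces phenyl, an at least 7.2-fold lower number from compound 2 to compound 4 (0.85 log units; beyond the scatter) when it replaces hydrogen and an at least 7.2-fold lower number from compound 1 to compound 4 (0.85 log units; beyond the scatter) when it replaces vinyl. These sizes are only floors and the steps among the three earlier compounds still cannot be read, because those compounds all sit at a limit of the assay: the limit of > 200000 nM in this assay, at which 3 of the 4 values shown sit.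

The change brings in a carbonyl and a bromine together, and the entering group has 9 heavy atoms against 6 for phenyl, so the compounds shown leave open which of these features accounts for the lower number. A plain phenylcarbonyl group or a (4-chlorophenyl)carbonyl group at the same place would begin to separate them, and an amine or a carboxylic acid on that chain would show whether the number can move further in either direction.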